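A few compounds are considered here, and "the series" means these few. Any claim that something is new, unique, unknown or untested is made for them only; others in the source may bear on it.

Of the compounds shown here, three built on one shared core have been tested in an ADME assay on HEK-293T cells (Homo sapiens) for cytotoxicity, read by CCK-8 assay, with a stated time of 48 h; on this read-out lower numbers stand for stronger inhibition and higher numbers for weaker inhibition. Compound 1 `O=C(Nc1cccc([N+](=O)[O-])c1)N1CCN(S(=O)(=O)c2sccc2-c2ccccc2Oc2ccc(O)c(O)c2)CC1` reports only a limit, > 20000 nM. Compound 2 `CC(C)c1ccc(Oc2ccc(O)c(O)c2)c(-c2ccsc2S(=O)(=O)NCCNC(=O)Nc2cc(C(F)(F)F)cc(C(F)(F)F)c2)c1` likewise reports only a limit, > 20000 nM. Among the compounds with values here, compound 3 `O=C(NCCNS(=O)(=O)c1sccc1-c1ccccc1Oc1ccc(O)c(O)c1)Nc1cc(C(F)(F)F)cc(C(F)(F)F)c1` is the sole compound with a number: in this assay compound 3 gives 8900 nM. Within the data shown here, the one measured step, an at least 2.2-fold lower number from compound 2 to compound 3 (0.35 log units; beyond the scatter), came from putting hydrogen in place of isopropyl on an aromatic carbon; its true size is bounded only from below because of the limit of > 20000 nM in this assay, at which 2 of the 3 values shown sit.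

Compound 4 `Cc1ccc(-c2ccsc2S(=O)(=O)NCCNC(=O)Nc2cc(C(F)(F)F)cc(C(F)(F)F)c2)c(Oc2ccc(O)c(O)c2)c1` is not yet measured. It differs from compound 3 by methyl in place of hydrogen on an aromatic carbon, the methyl sitting on the same aromatic carbon that carried the isopropyl in compound 2, meta to a 3,4-dihydroxyphenoxy group. This change runs back toward compound 2, and the number is expected to rise again, though a methyl is smaller than an isopropyl. The expected step is a 1.7-fold higher number from compound 3 to compound 4 (0.23 log units; within the scatter), a partial return toward the limit. Compound 4 is thus expected to give about 15000 nM in this assay, within 7000 nM to 35000 nM, with a fair chance that only a limit is reported.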

Compound 4, half-maximal inhibitory concentration: > 20000 nM
Compound 4: only a limit was reported; the forecaster's own chance of this, stated with the estimate: 45%; middle value at least 1.3-fold (0.12 log units) from the limit.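

In this assay, methyl in place of hydrogen on this aromatic carbon, meta to a 3,4-dihydroxyphenoxy group and para to a large group, gives an at least 2.2-fold higher number from compound 3 to compound 4 (0.35 log units; beyond the scatter), so a group of one heavy atom is already enough to reach the limit. Before this result, only the isopropyl change had shown such a loss, in an at least 2.2-fold lower number from compound 2 to compound 3 (0.35 log units; beyond the scatter), and it was not yet known whether a far smaller group on this aromatic ring would do the same. Among compound 2, compound 3 and compound 4, only compound 3, with hydrogen at both of these carbons, now gives a number, and the true size of the new step is bounded only from below, because of where the values sit: the limit of > 20000 nM in this assay, at which 3 of the 4 values shown sit.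

Compound 2 and compound 4 each report only a limit, so the compounds shown cannot tell whether methyl and isopropyl differ in this assay. Also open, from the compounds shown here alone, is what a fluorine, a methoxy group or an amine on this aromatic carbon would give, and whether any of them would yield a number, as hydrogen does in compound 3.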